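Replacing the Acid of Compound 1 with a Hydroxymethyl Group

The source may hold more compounds than are shown below. What is called first, only, known or untested is meant among the compounds shown, and "the series" means these compounds.

Compound 1, `C=CC(=O)Nc1ccc(Cn2nc(-c3ccc(Oc4ccccc4)cc3)cc2C(=O)O)cc1`, was tested in a functional assay on JeKo-1 cells (Homo sapiens) for inhibition, read by luminescence and CellTiter-Glo, with a stated time of 72 h; on this read-out lower numbers stand for stronger inhibition and higher numbers for weaker inhibition. In this assay compound 1 gives > 60000 nM, which is a limit of the assay and not a measured number. Compound 2, `C/C=C/C(=O)Nc1ccc(Cn2nc(-c3ccc(Oc4ccccc4)cc3)cc2C(=O)O)cc1`, likewise gives > 60000 nM, also a limit. Compound 3, `C/C=C/C(=O)Nc1cccc(Cn2nc(-c3ccc(Oc4ccccc4)cc3)cc2C(=O)OCC)c1`, gives 16700 nM. Within the data shown here, the only step measured in one place, a step that the two limits leave unreadable from compound 1 to compound 2, changes the group on the carbonyl carbon and not the acid, so it says nothing directly about the change considered here; it is unreadable anyway, since the limit of > 60000 nM in this assay, at which 2 of the 3 values shown sit, is where two of the three values sit. Compound 3 differs from compound 1 in several places at once, so only its value can be set beside that of compound 1.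

Compound 4, `C=CC(=O)Nc1ccc(Cn2nc(-c3ccc(Oc4ccccc4)cc3)cc2CO)cc1`, carries hydroxymethyl in place of carboxy on an aromatic carbon, that is, hydroxymethyl in place of carboxy on an aromatic carbon. Among the measured compounds shown here, no measured step touches this position. Compound 4 is therefore expected to land near 30000 nM, within 6000 nM to 60000 nM, which means an estimated step of an at least 2.0-fold lower number from compound 1 to compound 4 (0.30 log units; that floor lies within the scatter), with a real chance that only a limit is reported again.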

Compound 4, half-maximal inhibitory concentration: 8000 nM
For compound 4 the middle estimate is 3.8-fold (0.57 log units) above the measured one; the measured number falls inside the stated range.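

Hydroxymethyl in place of carboxy on this aromatic carbon of the five-membered ring gives in this assay an at least 7.5-fold lower number from compound 1 to compound 4 (0.87 log units; beyond the scatter) and so provides the first readable step at this position. The change lies beyond the usual scatter, so this one swap on the core of compound 1 is enough to bring a measured number into view. The true size of the step may be larger, because the starting point is a limit of the assay and not a measured number: the limit of > 60000 nM in this assay, at which 2 of the 4 values shown sit.

The compounds shown leave open whether the same step would appear with a methyl group, a primary amide or an amine on this carbon. They also leave open whether a longer chain ending in a hydroxyl group would give a lower or a higher number than hydroxymethyl.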